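Chain end of compound 2: pentyloxy to 4-hydroxybutyl

This account rests on a few compounds, and the source may have more. Where it says the series, first, only, none or still open, it means among the compounds named here.

Measured in a functional assay on K562 cells (Homo sapiens) for antiproliferative activity; a lower number here means a stronger inhibitor of growth, a higher number a weaker inhibitor of growth:
- compound 1 `COCCCCCCCCCCC/C=C1\CC(CO)(COC(=O)C(C)(C)C)OC1=O`: 0.516 ug/mL
- compound 2 `CCCCCOCCCCCCC/C=C1\CC(CO)(COC(=O)C(C)(C)C)OC1=O`: 1.15 ug/mL

Among the measured compounds shown here, of the two numbers so far, compound 2 holds the higher at 1.15 ug/mL, and compound 1 is its only neighbour. The next compound is compound 3 `CC(C)(C)C(=O)OCC1(CO)C/C(=C\CCCCCCCCCCCO)C(=O)O1`, which keeps the shared core and differs only in the chain: 4-hydroxybutyl in place of pentyloxy on a saturated chain carbon, seven bonds along the chain from a double-bonded chain carbon. In words, this is 4-hydroxybutyl in place of pentyloxy on a saturated chain carbon, seven bonds along the chain from a double-bonded chain carbon.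

A single measured step bears on this change: a 2.2-fold higher number from compound 1 to compound 2 (0.35 log units; beyond the scatter). It is modest and falls at the same place on the chain. For the measured compounds named here, no measured compound yet has 4-hydroxybutyl there, so the direction is weakly held. A step no larger than that one is expected, leaning towards a higher number in this assay. The expected change is a 1.3-fold higher number from compound 2 to compound 3 (0.12 log units; within the scatter). The estimate for compound 3 is 1.5 ug/mL, with an expected range of 0.5 ug/mL to 4.5 ug/mL.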

Compound 3, concentration for 50% growth inhibition: 1.09 ug/mL
The estimate for compound 3 lay 1.4-fold (0.14 log units) above the measured number, and the stated range covers the measured number.
By their numbers in this assay, from the lowest: compound 1; then compounds 3 and 2 (each within the scatter of the next).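

In this assay, 4-hydroxybutyl in place of pentyloxy on a saturated chain carbon, seven bonds along the chain from a double-bonded chain carbon, gives a 1.1-fold lower number from compound 2 to compound 3 (0.02 log units; within the scatter) and so leaves compound 2 and compound 3 unresolved, even though this change adds a hydrogen-bond donor and removes one heavy atom. Hydrogen in place of methyl on an oxygen on a saturated carbon gives a 2.1-fold higher number from compound 1 to compound 3 (0.32 log units; beyond the scatter) and is a modest step beyond the scatter, so compound 1 now stands apart from two different chain ends, 4-hydroxybutyl and pentyloxy, rather than from pentyloxy alone. Nothing on hand accounts for either step.

Going by these compounds, whether a carboxylic acid, an amine or a longer chain at this place would stay level with compound 2 and compound 3 or move away from them remains open. Also open, on these data alone, is whether the number of compound 1 is particular to its 4-methoxybutyl group or would be shared by an ethyl ether of the same chain length.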